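Compound 4: a pyridine swap awaiting its measurement

This account rests on a few compounds, and the source may have more. Where it says the series, first, only, none or still open, it means among the compounds named here.

compound 1 `CC(=O)N1N=C(c2ccc3ccccc3c2)OC1c1ccc(Br)cc1` gives 4.68 ug/mL
compound 2 `CC(=O)N1N=C(c2ccc3ccccc3c2)OC1c1ccc(Cl)cc1` gives 2.48 ug/mL
compound 3 `CC(=O)N1N=C(c2ccc3ccccc3c2)OC1c1ccc2ccccc2c1` gives 1.56 ug/mL
compound 4 `CC(=O)N1N=C(c2ccc3ccccc3c2)OC1c1cccnc1` has not been measured yet

In a functional assay on B16-F10 cells (Mus musculus) for antiproliferative activity, read by MTT assay, with a stated time of 48 h (on this read-out lower numbers stand for stronger inhibition and higher numbers for weaker inhibition), compound 2 gives 2.48 ug/mL and lies within the usual scatter of compound 3 at 1.56 ug/mL and also of compound 1 at 4.68 ug/mL on this read-out. The change to compound 4 puts pyridin-3-yl in place of 4-chlorophenyl on a saturated ring carbon, and pyridin-3-yl in place of 4-chlorophenyl on a saturated ring carbon sums it up.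

Among the compounds with values here, the one measured step is a 1.9-fold lower number from compound 1 to compound 2 (0.28 log units; within the scatter) for chloro in place of bromo on an aromatic carbon, and it lies within the scatter. Within the data shown here, that step keeps a ring of carbon only, so it is a weak guide here, and no measured compound has a ring with a hetero atom. On this evidence no step beyond the scatter is expected in this assay and no firm direction can be given. The expected step is a 1.2-fold higher number from compound 2 to compound 4 (0.08 log units; within the scatter) and it remains only an estimate. For compound 4 the estimate is 3 ug/mL and the expected range runs from 1 ug/mL to 9 ug/mL until a measurement arrives.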

Compound 4, half-maximal inhibitory concentration: 3.06 ug/mL
Compound 4: middle estimate off by 1.0-fold (0.01 log units), on the low side; low and high end bracket the measured number.
By their numbers in this assay, from the lowest: compounds 3, 2, 4 and 1 (each within the scatter of the next, the first and the last beyond it).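

In this assay, within the data shown here, a ring with a hetero atom stands for the first time on the saturated ring carbon, and the change to it gives a 1.2-fold higher number from compound 2 to compound 4 (0.09 log units; within the scatter) and a 1.5-fold lower number from compound 1 to compound 4 (0.18 log units; within the scatter). Pyridin-3-yl thus brings a ring nitrogen, counted as a hydrogen-bond acceptor, and removes the halogen, yet compound 4 cannot be told apart from either halogen-bearing compound on this read-out, so among these compounds the position accepts a ring of carbon only and a ring with one nitrogen alike. Nothing available explains why the number stays inside the scatter after this swap.

Only one placement of the ring nitrogen is shown, so it remains open whether pyridin-2-yl or pyridin-4-yl would behave in the same way, or whether a phenyl ring carrying an amine or a carboxylic acid, or a longer alkyl chain in place of the ring, would move the number beyond the scatter. Going by these compounds, the shared core and the acetyl group are the same in all four compounds, so what a change at either would do also remains open.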